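A few compounds are considered here, and "the series" means these few. Any claim that something is new, unique, unknown or untested is made for them only; others in the source may bear on it.

Measured compounds in this series:
- compound 1, `O=C(CCCCCCNC(=O)C(O)(O)C(F)(F)F)Nc1ccccc1`: 9140 nM
- compound 2, `O=C(CCCCCCNC(=O)C(O)(O)C(F)(F)F)Nc1ccc(S(F)(F)(F)(F)F)cc1`: 9110 nM

Compound 1 stands highest of the two numbers in a functional assay on HCT-116 cells (Homo sapiens) for inhibition, read by colorimetric assay, with a stated time of 3 days (on this read-out higher numbers stand for weaker inhibition and lower numbers for stronger inhibition), with compound 2 nearest: the step of a 1.0-fold lower number from compound 1 to compound 2 (0.00 log units; within the scatter) is within the scatter, so the two values are indistinguishable.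

The next compound to be measured is compound 3, `O=C(CCCCCCNC(=O)C(O)(O)C(F)(F)F)Nc1nccs1`. Relative to compound 1 the change is 1,3-thiazol-2-yl in place of phenyl on an amide-type nitrogen.

Going by the values given here, only one measured step exists, a 1.0-fold lower number from compound 1 to compound 2 (0.00 log units; within the scatter), and it concerns a substituent on the phenyl ring rather than the ring itself; it therefore does not bear directly on the exchange of the whole phenyl for the 1,3-thiazol-2-yl group. Among the compounds with values here, the one step that is known showed no movement beyond the scatter, and no measured pair speaks to an aromatic ring exchange at the amide-type nitrogen. Without such a pair, the expectation rests on compound 1 alone, and the expected step of a 1.0-fold lower number from compound 1 to compound 3 (0.01 log units; within the scatter) is set at no change beyond the scatter, with a wide band either side.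

On that basis compound 3 is expected to give about 9000 nM in this assay, within the range 3000 nM to 27000 nM.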

Compound 3, half-maximal inhibitory concentration: 10800 nM
Compound 3: the middle estimate sits 1.2-fold (0.08 log units) below what was measured, and the stated range covers the measured number.
By their numbers in this assay, from the lowest: compounds 2, 1 and 3 (each within the scatter of the next).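

In this assay, replacing phenyl with 1,3-thiazol-2-yl on the amide-type nitrogen gives a 1.2-fold higher number from compound 1 to compound 3 (0.07 log units; within the scatter), so at this position the whole aromatic ring can be exchanged, not only a substituent on it, without a step the read-out can separate from the scatter. The exchange swaps a six-membered aromatic ring of carbon only, with no hydrogen-bond acceptors, for a five-membered aromatic ring with 2 hetero atoms and 2 hydrogen-bond acceptors, yet like a 1.0-fold lower number from compound 1 to compound 2 (0.00 log units; within the scatter) it stays within the scatter, and so far neither change at this nitrogen has separated from compound 1. No supporting measurement is available to account for this flat picture.

Open, as far as these compounds go, is whether a saturated ring such as cyclohexyl in place of the aromatic ring, or a carboxylic acid or an amine on the aromatic ring, would move the number at this nitrogen. Also open, from the compounds shown here alone, is what a shorter or longer chain would do in this assay, the chain and the rest of the shared core being identical in all three compounds.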